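The compounds below may be only part of what the source reports. "The series", "measured", "known", "first", "only" and "open" are said of these compounds alone.

Measured so far in a functional assay on MKN-45 cells (Homo sapiens) for cytotoxicity, read by MTT assay, with a stated time of 72 h; a higher number here means a weaker inhibitor, a lower number a stronger inhibitor:

compound 1, `COc1cc2c(Oc3ccc(NC(=O)c4nn(-c5cccc(F)c5)c(=O)c5ccccc45)cc3F)ccnc2cc1OCCCN1CCCC1`, gives 160 nM
compound 2, `COc1cc2c(Oc3ccc(NC(=O)c4nn(-c5ccccc5F)c(=O)c5ccccc45)cc3F)ccnc2cc1OCCCN1CCCC1`, gives 140 nM
compound 3, `COc1cc2c(Oc3ccc(NC(=O)c4nn(-c5cccc(F)c5)c(=O)c5ccccc45)cc3F)ccnc2cc1OCCCN1CCC(C)CC1`, gives 220 nM

All three share one core and differ only at two points. Compound 3 differs from compound 1 by 4-methylpiperidin-1-yl in place of pyrrolidin-1-yl on a saturated chain carbon, three bonds along the chain from an oxygen on an aromatic ring, and that step, a 1.4-fold higher number from compound 1 to compound 3 (0.14 log units; within the scatter), did not move the number beyond the usual scatter. Compound 4, `COc1cc2c(Oc3ccc(NC(=O)c4nn(-c5ccccc5F)c(=O)c5ccccc45)cc3F)ccnc2cc1OCCCN1CCC(C)CC1`, is not yet measured. It differs from compound 3 by 2-fluorophenyl in place of 3-fluorophenyl on an aromatic nitrogen, the same change that turns compound 1 into compound 2, (2-fluorophenyl in place of 3-fluorophenyl on an aromatic nitrogen), with the surroundings of the place described in identical words. In this assay that earlier change gave a 1.1-fold lower number from compound 1 to compound 2 (0.06 log units; within the scatter), a step too small to count as a real difference. For the measured compounds named here, with only this one pair to go on, the expectation for compound 4 is a step of about the same size, a 1.1-fold lower number from compound 3 to compound 4 (0.04 log units; within the scatter), because the earlier change left the number essentially unchanged in a 1.1-fold lower number from compound 1 to compound 2 (0.06 log units; within the scatter). Compound 4 is therefore estimated at 200 nM, most likely between 100 nM and 400 nM.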

Compound 4, half-maximal inhibitory concentration: 260 nM
For compound 4 the middle estimate is 1.3-fold (0.11 log units) below the measured one; low and high end bracket the measured number.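

Swapping 3-fluorophenyl for 2-fluorophenyl gave a 1.2-fold higher number from compound 3 to compound 4 (0.07 log units; within the scatter) in this assay, and the same swap on the pyrrolidin-1-yl compounds gave a step that cannot be told apart from it: the same change on two cores in this assay, a 1.1-fold lower number (0.06 log units; within the scatter) from compound 1 to compound 2 and a 1.2-fold higher number (0.07 log units; within the scatter) from compound 3 to compound 4, 1.4-fold (0.13 log units) apart, within the scatter of two such steps

The other swap, 4-methylpiperidin-1-yl in place of pyrrolidin-1-yl, gave a 1.9-fold higher number from compound 2 to compound 4 (0.27 log units; within the scatter), and it also looks the same on both cores: the same change on two cores in this assay, a 1.4-fold higher number (0.14 log units; within the scatter) from compound 1 to compound 3 and a 1.9-fold higher number (0.27 log units; within the scatter) from compound 2 to compound 4, 1.4-fold (0.13 log units) apart, within the scatter of two such steps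

So in these four compounds each change carries from one core to the other without any detectable shift, but every step is small enough to be scatter, so this shows only that two changes with no clear effect stay without a clear effect, not that a change with a real effect would carry over in the same way.

The compounds shown leave open what a morpholin-4-yl at the end of the chain would do. They also leave open what an unsubstituted phenyl or a 4-fluorophenyl on the aromatic nitrogen would do, and whether either would move the number beyond the scatter.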